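Chloro in place of methyl: an expected clearance

This account rests on a few compounds, and the source may have more. Where it says the series, first, only, none or still open, it means among the compounds named here.

In an ADME assay on the whole organism (Mus musculus, strain CD1) for pharmacokinetics, at a dose of 2 mg/kg by the intravenous route (on this read-out higher numbers stand for fast clearance and lower numbers for slow clearance), the measured compounds read:
Compound 1 (`Cc1cc(N2C(=O)C3(CCC3)N(c3ccc(OC4CCNCC4)nc3)C2=S)cnc1C#N`) gives 19.4 mL/min/kg
Compound 2 (`N#Cc1ncc(N2C(=O)C3(CCC3)N(c3ccc(CN4CCNCC4)cc3)C2=S)cc1C(F)(F)F`) gives 18.2 mL/min/kg

Compound 1 stands level with compound 2, the two values lying within the usual scatter of each other. Compound 3 (`N#Cc1ncc(N2C(=O)C3(CCC3)N(c3ccc(OC4CCNCC4)nc3)C2=S)cc1Cl`) keeps the core of compound 1 but carries chloro in place of methyl on an aromatic carbon. Within the data shown here, no measured pair shows this change, so no step beyond the scatter is expected in this assay. The estimate gives a 1.1-fold lower number from compound 1 to compound 3 (0.03 log units; within the scatter) as the expected step. Compound 3 is estimated at 18 mL/min/kg with an expected range from 10 mL/min/kg to 33 mL/min/kg (an estimate, not a measurement).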

Compound 3, clearance: 25.4 mL/min/kg
Compound 3: middle estimate off by 1.4-fold (0.15 log units), on the low side; measured number inside the range.
By their numbers in this assay, from the lowest: compounds 2, 1 and 3 (each within the scatter of the next).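

Among these compounds, compound 1 and compound 3 form the only measured pair that differs at this position, the carbon ortho to a cyano group, and this assay reads it as a 1.3-fold higher number from compound 1 to compound 3 (0.12 log units; within the scatter) for chloro in place of methyl. On this read-out, the pair therefore does not separate the two groups at this position. No measured evidence bears on the reading of this pair.

The compounds shown leave open how methoxy, ethyl or an amine on this carbon would read with the rest of compound 1 kept. They also leave open whether the same swap would read alike on another core.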